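The source may hold more compounds than are shown below. What is called first, only, known or untested is meant among the compounds shown, and "the series" means these compounds.

Measured so far in an in vivo ADME assay on the whole organism (plasma) with Mus musculus as the target, at a dose of 100 mg/kg by the oral route; a higher number here means more compound in the circulation at the dose given, a lower number less compound in the circulation:
- compound 1 `C#C/C=C(\c1cccc(F)c1)c1ccc2nc(N)n(S(=O)(=O)C(C)C)c2c1` gives 31300 nM
- compound 2 `C#C/C=C(/c1ccc2nc(N)n(S(=O)(=O)C(C)C)c2c1)c1cc(F)ccc1F` gives 23200 nM
- compound 3 `C#C/C=C(\c1ccc(OC)c(F)c1)c1ccc2nc(N)n(S(=O)(=O)C(C)C)c2c1` gives 22300 nM

Compound 1 has the highest number of the three, but its steps to the other two are both within the scatter, so the three compounds are not separated by this assay: a 1.3-fold lower number from compound 1 to compound 2 (0.13 log units; within the scatter) and a 1.4-fold lower number from compound 1 to compound 3 (0.15 log units; within the scatter). Compound 2 and compound 3 likewise sit close together, a 1.0-fold lower number from compound 2 to compound 3 (0.02 log units; within the scatter).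

The unmeasured compound 4 `C#C/C=C(\c1cccc(C(F)(F)F)c1)c1ccc2nc(N)n(S(=O)(=O)C(C)C)c2c1` comes from compound 1 by a change on the pendant phenyl ring: trifluoromethyl in place of fluoro on an aromatic carbon. The two measured steps from compound 1 touch the same region of the molecule, each adding a small group on an aromatic carbon, and neither moved the number beyond the scatter. Nothing measured here speaks to a trifluoromethyl group in particular; the expectation therefore rests on the flatness seen so far. No step beyond the scatter is expected, a 1.3-fold lower number from compound 1 to compound 4 (0.10 log units; within the scatter), and compound 4 is estimated at 25000 nM in this assay, with a range from 11000 nM to 55000 nM.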

Compound 4, maximal plasma concentration: 11300 nM
Compound 4: the middle estimate sits 2.2-fold (0.34 log units) above what was measured; the measured number falls inside the stated range.
By their numbers in this assay, from the lowest: compounds 4, 3, 2 and 1 (each within the scatter of the next, the first and the last beyond it).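

Among these compounds, at this place on the aromatic carbon, meta to a large group, trifluoromethyl in place of fluoro gives the first step in this assay that leaves the scatter, a 2.8-fold lower number from compound 1 to compound 4 (0.44 log units; beyond the scatter), so the flat picture from compounds 1, 2 and 3 does not extend to every group here. Compound 4 also separates from the 2,5-difluorophenyl analogue, a 2.1-fold lower number from compound 2 to compound 4 (0.31 log units; beyond the scatter), but not from the 3-fluoro-4-methoxyphenyl analogue, a 2.0-fold lower number from compound 3 to compound 4 (0.30 log units; within the scatter), so the separation holds against only two of the three other compounds. Nothing available accounts for the lower number with trifluoromethyl.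

Open, as far as these compounds go, is what a methyl, a nitrile or an amine on the same aromatic carbon would give. Also open, from the compounds shown here alone, is whether trifluoromethyl elsewhere on this ring would give a step of the same size.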